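The compounds below may be only part of what the source reports. "The series", "measured", "known", "first", "only" and "open" are said of these compounds alone.

Compound 1 `O=C(O)c1ccc(-c2nc3cccnc3n2C2CCCC2)cc1`: 600 nM
Compound 2 `O=C(NC1CC1)c1ccc(-c2nc3cccnc3n2C2CCCC2)cc1`: 115 nM
Compound 3 `CN(C)C(=O)c1ccc(-c2nc3cccnc3n2C2CCCC2)cc1`: 520 nM

These values come from a functional assay on MDA-MB-231 cells (Homo sapiens) for cytotoxicity, read by MTT assay, with a stated time of 24 h; on this read-out lower numbers stand for stronger inhibition and higher numbers for weaker inhibition. Compound 3 stands level with compound 1, a 1.2-fold lower number from compound 1 to compound 3 (0.06 log units; within the scatter), and well clear of compound 2, a 4.5-fold higher number from compound 2 to compound 3 (0.66 log units; beyond the scatter).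

Compound 4 `c1cnc2c(c1)nc(-c1ccc(-c3nnco3)cc1)n2C1CCCC1` carries 1,3,4-oxadiazol-2-yl in place of dimethylcarbamoyl on an aromatic carbon.

Going by the values given here, no measured step replaces the carbonyl group itself. Those nearest vary only its substituent, the largest being modest: a 5.2-fold lower number from compound 1 to compound 2 (0.72 log units; beyond the scatter). They give only a loose guide, so no clear direction is expected, and probably no shift beyond the scatter.

The expected change is a 1.3-fold lower number from compound 3 to compound 4 (0.11 log units; within the scatter).

The estimate for compound 4 is 400 nM, with an expected range of 120 nM to 1300 nM.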

Compound 4, half-maximal inhibitory concentration: 87 nM
Compound 4: the middle estimate sits 4.6-fold (0.66 log units) above what was measured; measured number outside the range, below it.
By their numbers in this assay, from the lowest: compounds 4 and 2 (each within the scatter of the next); then compounds 3 and 1 (each within the scatter of the next).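

The carbonyl group itself can be given up at this position: 1,3,4-oxadiazol-2-yl, with its five-membered aromatic ring, improves on dimethylcarbamoyl (a 6.0-fold lower number from compound 3 to compound 4 (0.78 log units; beyond the scatter)) and on carboxy (a 6.9-fold lower number from compound 1 to compound 4 (0.84 log units; beyond the scatter)), and stands level with cyclopropylcarbamoyl (a 1.3-fold lower number from compound 2 to compound 4 (0.12 log units; within the scatter)). The low number therefore no longer belongs to compound 2 alone, and it does not depend on an amide hydrogen, which compound 4 lacks. No measurement shown accounts for the gain over dimethylcarbamoyl.

Still open, going by these compounds, is whether this particular ring arrangement matters, since a 1,2,4-oxadiazole or a 1,3,4-thiadiazole at the same place would test it. The primary amide also remains unplaced in this series.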